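The compounds below may be only part of what the source reports. "The series", "measured", "known", "first", "only" and "open" are said of these compounds alone.

Measured compounds:
Compound 1 `O=C1C[C@H](O)C[C@@H](/C=C/c2c(F)cc(F)cc2-c2ccc(F)cc2)O1` gives 860 nM in an assay for inhibition of 3-hydroxy-3-methylglutaryl-coenzyme A reductase (Rattus norvegicus); on this read-out higher numbers stand for weaker inhibition and lower numbers for stronger inhibition.
Compound 2 `O=C1C[C@H](O)C[C@@H](/C=C/c2c(Cl)cc(Cl)cc2-c2ccc(Cl)c(Cl)c2)O1` gives 25 nM in this assay.
Compound 3 `Cc1cc(C)c(/C=C/[C@@H]2C[C@@H](O)CC(=O)O2)c(-c2cc(C)c(F)c(C)c2)c1` gives 10 nM in this assay.

Among these three numbers, compound 2 stands second highest. Its nearest neighbour is compound 3, whose number is lower by a margin beyond the scatter, while compound 1 lies far above it, also beyond the scatter. Within the data shown here, no two of the measured compounds differ in a single place, so no measured step can be attached to the change now under consideration.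

Compound 4 `O=C1C[C@H](O)C[C@@H](/C=C/c2c(Cl)cc(Cl)cc2-c2cccc(F)c2)O1` is not yet measured. It differs from compound 2 in one place: 3-fluorophenyl in place of 3,4-dichlorophenyl on an aromatic carbon. The chlorine-bearing compound 2 is the stronger of the two halogen-rich compounds, and compound 1, which carries only fluorine, gives 860 nM; on that basis the account expects the step from compound 2 to compound 4 to run toward weaker inhibition, by a 3.2-fold higher number from compound 2 to compound 4 (0.51 log units; beyond the scatter). For compound 4 the expected value in this assay is 80 nM, with a likely range from 25 nM to 260 nM.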

Compound 4, half-maximal inhibitory concentration: 70 nM
The estimate for compound 4 lay 1.1-fold (0.06 log units) above the measured number, and the stated range covers the measured number.
By their numbers in this assay, from the lowest: compound 3; then compound 2; then compound 4; then compound 1.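

In this assay, among these compounds, this is the first reading of a single change at this place, an aromatic carbon ortho to a large group: 3-fluorophenyl in place of 3,4-dichlorophenyl gives a 2.8-fold higher number from compound 2 to compound 4 (0.45 log units; beyond the scatter) and so shows that inhibition responds to what this aryl group carries. The size of the step is modest, so the change weakens inhibition without abolishing it. No measurement shown here accounts for the step.

The change replaces one halogen and removes another in the same step, and the compounds shown do not separate these two parts. As far as these compounds go, it also remains open how inhibition would respond if this aryl group carried a methoxy group or an amine instead of a halogen.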